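Hydroxycycloalkyl to methoxycyclohexyl on the aminopyridine core

The source may hold more compounds than are shown below. What is called first, only, known or untested is meant among the compounds shown, and "the series" means these compounds.

Measured compounds:
compound 1 `N#Cc1cnc(NCc2cnccc2C(F)(F)F)cc1N[C@H]1C[C@@H](O)C1`: 500 nM
compound 2 `N#Cc1cnc(NCc2cnccc2C(F)(F)F)cc1N[C@H]1CC[C@@H](O)CC1`: 100 nM
compound 3 `N#Cc1cnc(NCc2cnccc2C(F)(F)F)cc1N[C@H]1CC[C@H](O)CC1`: 350 nM

In an assay on isolated protein for inhibition of protein kinase C theta type (Homo sapiens), read by TR-FRET, with a stated time of 2 h (a lower number here means a stronger inhibitor, a higher number a weaker inhibitor), compound 1 gives the highest number of the three. The nearest is compound 3 a 1.4-fold lower number from compound 1 to compound 3 (0.15 log units; within the scatter), the furthest compound 2 a 5.0-fold lower number from compound 1 to compound 2 (0.70 log units; beyond the scatter); the gap between those two rests on (the fact that compounds 2 and 3 differ only in the configuration as drawn), seen as a 3.5-fold higher number from compound 2 to compound 3 (0.54 log units; beyond the scatter).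

Compound 4 `CO[C@H]1CC[C@@H](Nc2cc(NCc3cnccc3C(F)(F)F)ncc2C#N)CC1` carries the change (4-methoxycyclohexyl in place of 3-hydroxycyclobutyl on a nitrogen on an aromatic ring). For the measured compounds named here, both measured steps from compound 1 enlarge the ring in the same way, and both lower the number, one beyond the scatter, one within it; the hydroxyl becoming a methoxy has no measured counterpart here. A modest step downward in this assay is therefore expected, a 3.3-fold lower number from compound 1 to compound 4 (0.52 log units; beyond the scatter).

Compound 4 is estimated at 150 nM, within 50 nM to 500 nM.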

Compound 4, half-maximal inhibitory concentration: 58 nM
Estimate against measurement, compound 4: 2.6-fold (0.41 log units) above; the measured number falls inside the stated range.
By their numbers in this assay, from the lowest: compounds 4 and 2 (each within the scatter of the next); then compounds 3 and 1 (each within the scatter of the next).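

In this assay, methyl in place of hydrogen on the oxygen leaves compound 2 and compound 4 level, a 1.7-fold lower number from compound 2 to compound 4 (0.24 log units; within the scatter), so within the configuration of compound 2 the 4-substituted cyclohexyl keeps its standing without a hydroxyl hydrogen. The step of a 6.0-fold lower number from compound 3 to compound 4 (0.78 log units; beyond the scatter) joins that methyl with the change in configuration, and the whole change from 3-hydroxycyclobutyl gives an 8.6-fold lower number from compound 1 to compound 4 (0.94 log units; beyond the scatter). The size of the ring and the configuration therefore carry these steps, not the methyl.

Still open, going by these compounds, is how 4-methoxycyclohexyl behaves in the configuration of compound 3. Also open, on these data alone, is whether an ethoxy or an amine in place of the methoxy would hold this level.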